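The compounds below may be only part of what the source reports. "The series", "measured", "known", "first", "only" and "open" are said of these compounds alone.

Among the measured compounds shown here, compound 1 `COc1cccc(CNCCCNc2ccnc3cc(CCC(C)C)ccc23)c1O` is one of two compounds measured in an ADME assay on HepG2 cells (Homo sapiens) for cytotoxicity, read by luminescence, CellTiter-Glo and ATP content, with a stated time of 72 h; a lower number here means that less compound is needed, a higher number that more compound is needed for the effect. In this assay compound 1 gives 5390 nM, the highest of the two numbers; its nearest neighbour, compound 2 `COc1ccc(F)cc1CNCCCNc1ccnc2cc(CCC(C)C)ccc12`, gives 890 nM in this assay. For the measured compounds named here, the only step recorded, a 6.1-fold lower number from compound 1 to compound 2 (0.78 log units; beyond the scatter), swaps the aromatic group on the saturated chain carbon bound to the amine nitrogen. Compound 3 `COc1ccccc1Oc1ccc2c(NCCCNCc3cccc(OC)c3O)ccnc2c1` differs from compound 1 elsewhere: 2-methoxyphenoxy in place of isopentyl on an aromatic carbon. Going by the values given here, no measured step touches this aromatic carbon of the shared core, so the step from compound 1 to compound 2 does not bear on the change in hand, and there is no basis for expecting a shift in this assay beyond the scatter in either direction. Compound 3 is therefore estimated to give about 5000 nM in this assay, within a range of 1500 nM to 16000 nM, which means an expected step of a 1.1-fold lower number from compound 1 to compound 3 (0.03 log units; within the scatter).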

Compound 3, half-maximal effective concentration: 11200 nM
Compound 3: middle estimate off by 2.2-fold (0.35 log units), on the low side; low and high end bracket the measured number.
By their numbers in this assay, from the lowest: compound 2; then compound 1; then compound 3.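

Among the compounds shown here, this is the first measured change at this aromatic carbon of the shared core, and it shows that the position matters in this assay: with 2-methoxyphenoxy in place of isopentyl, there is a 2.1-fold higher number from compound 1 to compound 3 (0.32 log units; beyond the scatter). The step is modest, but it means that more compound is needed for the effect once this aromatic ether group replaces the open carbon chain. Nothing available explains why the number moves.

As far as these compounds go, with a single replacement at this position, it stays open whether the higher number goes with the added ring, the oxygen joining it to the core or its methoxy group. An unsubstituted phenyl or phenoxy group at this carbon would help separate these, and the same swap on compound 2 would test whether the step carries over to the 5-fluoro-2-methoxyphenyl series.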